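The source may hold more compounds than are shown below. What is called first, only, known or untested is meant among the compounds shown, and "the series" means these compounds.

Measured in a functional assay on DU-145 cells (Homo sapiens) for antiproliferative activity, read by MTT assay, with a stated time of 72 h; a higher number here means a weaker inhibitor, a lower number a stronger inhibitor:
Compound 1 `CCN(CC)CCCOc1cc2ncnc(Nc3ccc(C#N)cc3)c2cc1OC`: 68900 nM
Compound 2 `COc1cc2c(Nc3ccc(C#N)cc3)ncnc2cc1OCCCN1CCCCC1CCO`: > 100000 nM (a limit of the assay, not a number)
Compound 3 `COc1cc2c(Nc3ccc(C#N)cc3)ncnc2cc1OCCCN1CCC(c2ccccc2)CC1`: 6790 nM

The three compounds differ only in the group carried on the chain. Compound 3 is the strongest inhibitor of the three, with the lowest number, 6790 nM. Swapping in its 4-phenylpiperidin-1-yl group gave large steps: a 10-fold lower number from compound 1 to compound 3 (1.01 log units; beyond the scatter) and an at least 14-fold lower number from compound 2 to compound 3 (1.16 log units; beyond the scatter). The remaining step, an at least 1.4-fold higher number from compound 1 to compound 2 (0.16 log units; that floor lies within the scatter), rests on a limit, and its floor lies within the scatter, so it sets no order between those two.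

Compound 4 `COc1cc2c(Nc3ccc(C#N)cc3)ncnc2cc1OCCCN1CCC(N2CCCCC2)CC1` keeps everything in compound 3 except one group piperidin-1-yl in place of phenyl on a saturated ring carbon, which turns 4-phenylpiperidin-1-yl into 4-(piperidin-1-yl)piperidin-1-yl. Going by the values given here, no measured step makes this exact swap, so the closest guide is what happens without the phenyl. Compound 1, which has no phenyl on that group, gives 68900 nM, and compound 2, also without it, was the other large step away. A weaker result is therefore expected, most of the way back towards compound 1. The expected step is a 5.2-fold higher number from compound 3 to compound 4 (0.71 log units; beyond the scatter), a weakening beyond the scatter. For compound 4 the estimated value is 35000 nM, with an expected range of 10000 nM to 100000 nM.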

Compound 4, half-maximal inhibitory concentration: 15600 nM
For compound 4 the middle estimate is 2.2-fold (0.35 log units) above the measured one; the measured number falls inside the stated range.
By their numbers in this assay, from the lowest: compound 3; then compound 4; then compound 1. At a limit, above all of these: compound 2.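

In this assay, the phenyl of compound 3 can give way to piperidin-1-yl, a six-membered non-aromatic ring with the same count of heavy atoms, at a modest cost (a 2.3-fold higher number from compound 3 to compound 4 (0.36 log units; beyond the scatter)). Compound 4 still keeps a modest gain over the diethylamino group (a 4.4-fold lower number from compound 1 to compound 4 (0.65 log units; beyond the scatter)), so among these compounds an aromatic ring on this saturated ring carbon is not the only six-membered ring that goes with a lower number than diethylamino, although the phenyl of compound 3 gives the lowest number. The comparison with the 2-(2-hydroxyethyl)piperidin-1-yl group gives only a floor (an at least 6.4-fold lower number from compound 2 to compound 4 (0.80 log units; beyond the scatter)), and it rests on a limit of the assay, not a number: (the limit of > 100000 nM in this assay, at which 1 of the 4 values shown sits).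

The swap changes two things at once, removing the aromatic ring and bringing in a ring nitrogen, and the compounds shown cannot tell these two changes apart. A cyclohexyl group on the same carbon, a non-aromatic ring of carbon only, would separate them, and a morpholin-4-yl group would show whether a second hetero atom in the entering ring moves the number further.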